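Side-chain carbamate variant of a quinazoline ATM inhibitor series

The compounds below may be only part of what the source reports. "The series", "measured", "known", "first", "only" and "open" are said of these compounds alone.

Compound 1 `COc1ccc2ncnc(-n3nc(-c4ccccn4)nc3N)c2c1` — 16900 nM
Compound 2 `COc1cc2ncnc(-n3nc(-c4ccccn4)cc3N)c2cc1OC` — 1600 nM
Compound 3 `COc1cc2ncnc(-n3nc(-c4ccccn4)nc3N)c2cc1OCCCNC(=O)CN1C[C@@H](C)O[C@@H](C)C1` — 1700 nM

Of the compounds shown here, three have been measured in an assay on MCF7 cells for inhibition of Serine-protein kinase ATM (Homo sapiens), read by immunofluorescence, with a stated time of 1 h; a lower number here means a stronger inhibitor, a higher number a weaker inhibitor. Compound 1 gives 16900 nM, compound 2 gives 1600 nM, and compound 3 gives 1700 nM. Compound 3 stands second highest of the three numbers; its nearest neighbour is compound 2, whose value lies within the scatter of it, so no order between those two can be read. Compound 1 is the furthest away, with a number clearly higher than that of compound 3, beyond the scatter.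

Compound 4 `CCCCCCOC(=O)NCCCOc1cc2c(-n3nc(-c4ccccn4)nc3N)ncnc2cc1OC` has not yet been measured. It differs from compound 3 in one place: hexyloxy in place of (2,6-dimethylmorpholin-4-yl)methyl on a carbonyl carbon. The amide of compound 3 thus becomes a carbamate in compound 4, with the chain otherwise kept. No step between measured compounds shows the effect of such a change, so there is nothing in the shown numbers to set a direction. The step from compound 3 to compound 4 in this assay is therefore expected to be small, a 1.2-fold higher number from compound 3 to compound 4 (0.07 log units; within the scatter), possibly none beyond the scatter. Compound 4 is estimated at 2000 nM, within a range of 600 nM to 6500 nM.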

Compound 4, half-maximal inhibitory concentration: 28600 nM
Compound 4: middle estimate off by 14-fold (1.16 log units), on the low side; measured number above the stated range.
By their numbers in this assay, from the lowest: compounds 2 and 3 (each within the scatter of the next); then compounds 1 and 4 (each within the scatter of the next).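

In this assay, putting hexyloxy in place of (2,6-dimethylmorpholin-4-yl)methyl on a carbonyl carbon gives a 17-fold higher number from compound 3 to compound 4 (1.23 log units; beyond the scatter), a large step towards weaker inhibition. Among the compounds shown here, this is the first single-place comparison, and it shows that the group on this carbonyl carbon is not interchangeable: the inhibition seen with compound 3 does not survive this exchange, even though the rest of the molecule is kept. No measurement shown here bears on the reason for the step.

The one step changes several things at once, since the ring and its two defined stereocentres leave, and the amide becomes a carbamate, so the compounds shown do not separate these contributions. Going by these compounds, it remains open whether a shorter group such as ethoxy or butoxy on the same carbonyl carbon would behave like hexyloxy, and whether a hexyl group attached directly to the carbonyl carbon, or a (2,6-dimethylmorpholin-4-yl)ethoxy group in the same place, would stay closer to compound 3.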